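Amide aryl variation on a shared core

A few compounds are considered here, and "the series" means these few. Any claim that something is new, unique, unknown or untested is made for them only; others in the source may bear on it.

Measured compounds in a functional assay on MDA-MB-468 cells (Homo sapiens) for antiproliferative activity, read by MTT assay, with a stated time of 72 h; a lower number here means a stronger inhibitor, a higher number a weaker inhibitor:
Compound 1 `O=C(Nc1ccc(Cl)c(-c2nnc3c(Cl)cccn23)c1)c1cccnc1` gives > 100000 nM, which is a limit of the assay and not a number.
Compound 2 `O=C(Nc1ccc(Cl)c(-c2nnc3c(Cl)cccn23)c1)c1cccc(Cl)c1` gives 54800 nM.

Compound 1 stands only at a limit in this assay; no number is known for it. For the measured compounds named here, the single measured step, an at least 1.8-fold lower number from compound 1 to compound 2 (0.26 log units; that floor lies within the scatter), is the only one bearing on compound 3 `O=C(Nc1ccc(Cl)c(-c2nnc3c(Cl)cccn23)c1)c1ccc(Cl)cc1Cl`, which differs from compound 1 by 2,4-dichlorophenyl in place of pyridin-3-yl on a carbonyl carbon. On these data alone, that step is bounded by the limit of > 100000 nM in this assay, at which 1 of the 2 values shown sits, so its true size stays open; what it shows is that a chlorinated phenyl on the carbonyl carbon did not raise the number, and compound 3 carries the 2,4-dichlorophenyl at the same carbonyl carbon. Compound 3 is therefore expected in this assay to give 40000 nM, with a range from 15000 nM to 100000 nM. The expected step of an at least 2.5-fold lower number from compound 1 to compound 3 (0.39 log units; beyond the scatter) is read against a limit and so is itself only a floor.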

Compound 3, half-maximal inhibitory concentration: 21600 nM
Compound 3: middle estimate off by 1.9-fold (0.27 log units), on the high side; low and high end bracket the measured number.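

In this assay, for the compounds shown here, the 2,4-dichlorophenyl on the carbonyl carbon gives the only step here with a number at both ends and a size beyond the scatter, a modest one against the 3-chlorophenyl: a 2.5-fold lower number from compound 2 to compound 3 (0.40 log units; beyond the scatter). The step from the pyridin-3-yl, an at least 4.6-fold lower number from compound 1 to compound 3 (0.66 log units; beyond the scatter), is also beyond the scatter, but it is read against a limit of the assay and so stands only as a floor: the limit of > 100000 nM in this assay, at which 1 of the 3 values shown sits. Compound 3 still gives 21600 nM, so the measured change at this place remains modest.

On these data alone, it stays open how an unsubstituted phenyl, a methoxyphenyl or an aminophenyl on the carbonyl carbon would compare with these aryl groups. As far as these compounds go, whether a carboxylic acid on that ring would move the number in either direction is also open.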